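Swapping acetyl for trifluoromethyl on compound 3

This account rests on a few compounds, and the source may have more. Where it says the series, first, only, none or still open, it means among the compounds named here.

compound 1 `O=C(Nc1ccc(C(F)(F)F)cc1)c1cc(Cl)ccc1O`: 2200 nM
compound 2 `O=Cc1ccc(O)c(C(=O)Nc2ccc(C(F)(F)F)cc2)c1`: 21500 nM
compound 3 `CC(=O)c1ccc(NC(=O)c2cc(Br)ccc2O)cc1`: 18600 nM

All three compounds were tested in a functional assay on MONO-MAC-6 cells (Homo sapiens) for cytotoxicity, read by MTT assay, with a stated time of 24 h; on this read-out lower numbers stand for stronger inhibition and higher numbers for weaker inhibition. Compound 3 gives 18600 nM, which lies within the scatter of compound 2, while its number is clearly higher than that of compound 1 at 2200 nM.

The next compound to be measured is compound 4 `O=C(Nc1ccc(C(F)(F)F)cc1)c1cc(Br)ccc1O`, which carries trifluoromethyl in place of acetyl on an aromatic carbon. Among the compounds with values here, no measured step covers this exact swap. Within the data shown here, the only single-change step available is a 9.8-fold higher number from compound 1 to compound 2 (0.99 log units; beyond the scatter), with formyl in place of chloro. It involves different groups, so it bears only indirectly, showing that one swap among these compounds can move the number beyond the scatter.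

The closer guide is compound 1, which has the trifluoromethyl of compound 4 and differs from it by carrying chloro where compound 4 carries bromo. The expectation for compound 4 therefore leans on compound 1 at 2200 nM, and a fall in the number is expected, beyond the scatter. The expected change is a 7.4-fold lower number from compound 3 to compound 4 (0.87 log units; beyond the scatter). For compound 4 the estimated value is 2500 nM, with an expected range from 1000 nM to 6500 nM.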

Compound 4, half-maximal inhibitory concentration: 2000 nM
The estimate for compound 4 lay 1.3-fold (0.10 log units) above the measured number; the range from low to high includes it.
By their numbers in this assay, from the lowest: compounds 4 and 1 (each within the scatter of the next); then compounds 3 and 2 (each within the scatter of the next).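

In this assay, within the data shown here, the swap of acetyl for trifluoromethyl, on an aromatic carbon para to a large group, gives a 9.3-fold lower number from compound 3 to compound 4 (0.97 log units; beyond the scatter) and so provides the first direct reading of this change, showing that this position can shift the number beyond the scatter with the rest of the molecule held constant. At the other site that varies, the two halogens cannot be told apart, with bromo in place of chloro giving a 1.1-fold lower number from compound 1 to compound 4 (0.04 log units; within the scatter) as the step. Bromo in place of formyl at that same site gives an 11-fold lower number from compound 2 to compound 4 (1.03 log units; beyond the scatter) and thus, among these compounds, both sites matter: the pair carrying trifluoromethyl together with a halogen sits apart from compounds with acetyl or formyl in either place.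

The compounds shown leave open how an amine, a carboxylic acid or a longer chain would behave in place of trifluoromethyl, and whether iodo or a methoxy group would match chloro and bromo at the other site. Nothing given here accounts for why these swaps have the effects seen.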